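Swapping a hydroxy for diisopropylamino in a lipid-like chain

The compounds below may be only part of what the source reports. "The series", "measured", "known", "first", "only" and "open" are said of these compounds alone.

Measured compounds:
- Compound 1, `CCCCCCCCCCCCCC[C@H](O)[C@H](CO[Si](c1ccccc1)(c1ccccc1)C(C)(C)C)NC(=O)OC(C)(C)C`: 2.79%
- Compound 2, `CCCCCCCCCCCCCC[C@H](OCOC)[C@H](CO)NC(=O)OC(C)(C)C`: 10.2%

Both compounds were tested in a functional assay on MCF7 cells (Homo sapiens) for antiproliferative activity, read by sulforhodamine B assay, with a stated time of 48 h, tested at 10 uM; on this read-out higher numbers stand for more inhibition at the one concentration tested (going by the name of the read-out) and lower numbers for less inhibition. Compound 1 gives 2.79% there, and compound 2 gives 10.2%. The gap between the two lies within the usual scatter of this assay, so compound 2 and compound 1 cannot be told apart; both show little inhibition at the single concentration tested.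

Compound 3, `CCCCCCCCCCCCCC[C@H](OCOC)[C@H](CN(C(C)C)C(C)C)NC(=O)OC(C)(C)C`, has not yet been measured. It differs from compound 2 by one change: diisopropylamino in place of hydroxy on a saturated chain carbon, two bonds along the chain from an amide-type nitrogen. Among the measured compounds shown here, no pair of measured compounds shows what such a change does here, so there is nothing to lean on beyond the low numbers already seen. The step of a number 4.8 percentage points higher from compound 2 to compound 3 (within the scatter) is expected to be small, not clearly beyond the scatter. Compound 3 is therefore expected to give about 15%, with a plausible range from 0% to 40%.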

Compound 3, a percentage reported as inhibition, at one concentration (the size of the read-out at that concentration, not a potency): 26.9%
Beside the measured number, compound 3's estimate is 11.9 percentage points below it, within the range that was stated.
By their numbers in this assay, from the lowest: compounds 1 and 2 (each within the scatter of the next); then compound 3.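

In this assay, among the compounds shown here, a number 16.7 percentage points higher from compound 2 to compound 3 (beyond the scatter) gives the first evidence that this position responds to what is attached there: the step is modest, but it clears the usual scatter. It also shows that the hydroxy, with its hydrogen-bond donor, is not required for this level of inhibition, since the diisopropylamino that replaces it has no such donor. No measurement shown explains why the number goes up.

From the compounds shown here alone, it remains open whether this gain is specific to diisopropylamino or would also appear with a smaller amine such as dimethylamino, or with a carboxylic acid at the same place. With only one concentration tested, these numbers also leave open how potent compound 3 is.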